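Moving the chlorine on the amide aryl ring: a repeat test

This account rests on a few compounds, and the source may have more. Where it says the series, first, only, none or still open, it means among the compounds named here.

Two pairs of compounds share one structural change. Compound 1 `Cc1noc(C)c1-c1cnc(N)c(Oc2ccc(C(=O)Nc3ccccc3Cl)cc2)n1` and compound 2 `Cc1noc(C)c1-c1cnc(N)c(Oc2ccc(C(=O)Nc3ccc(Cl)cc3)cc2)n1` differ by 4-chlorophenyl in place of 2-chlorophenyl on an amide-type nitrogen. In a functional assay on HeLa cells (Homo sapiens) for inhibition, read by MTT assay, with a stated time of 72 h (on this read-out lower numbers stand for stronger inhibition and higher numbers for weaker inhibition), compound 1 gives 81300 nM, while compound 2 gives 2230 nM; the change made a 36-fold lower number from compound 1 to compound 2 (1.56 log units; beyond the scatter).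

Compound 3 `Cn1cc(-c2cnc(N)c(Oc3ccc(C(=O)Nc4ccccc4Cl)cc3)n2)cn1` carries a different core, and 1-methyl-1H-pyrazol-4-yl in place of 3,5-dimethyl-1,2-oxazol-4-yl on an aromatic carbon describes how the core of compound 3 differs from that of compound 1. In this assay compound 3 gives 73000 nM, which is a 1.1-fold lower number from compound 1 to compound 3 (0.05 log units; within the scatter), so the two cores behave alike in the form carrying the 2-chlorophenyl group.

Compound 4 `Cn1cc(-c2cnc(N)c(Oc3ccc(C(=O)Nc4ccc(Cl)cc4)cc3)n2)cn1` is not yet measured. It stands to compound 3 as compound 2 stands to compound 1: 4-chlorophenyl in place of 2-chlorophenyl on an amide-type nitrogen. The place of the change is described in the same words in both pairs, so the change is the same one, made on a different core.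

Among the compounds with values here, the expectation rests on compound 1 and compound 2, because a 36-fold lower number from compound 1 to compound 2 (1.56 log units; beyond the scatter) is the only measured example of this change, and on the close values of compound 1 and compound 3. Compound 4 is therefore expected to give 2200 nM in this assay, with a range of 700 nM to 8000 nM. That estimate means a step of a 33-fold lower number from compound 3 to compound 4 (1.52 log units; beyond the scatter), expected to resemble the earlier one; how far the new core follows the old is uncertain, so the range is wide.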

Compound 4, half-maximal inhibitory concentration: 3440 nM
Estimate against measurement, compound 4: 1.6-fold (0.19 log units) below; the measured number falls inside the stated range.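

On the core of compound 3, 4-chlorophenyl in place of 2-chlorophenyl gives a 21-fold lower number from compound 3 to compound 4 (1.33 log units; beyond the scatter), so the large step seen on the first core appears again in the same direction, and its size on the two cores cannot be told apart: the same change on two cores in this assay, a 36-fold lower number (1.56 log units; beyond the scatter) from compound 1 to compound 2 and a 21-fold lower number (1.33 log units; beyond the scatter) from compound 3 to compound 4, 1.7-fold (0.24 log units) apart, within the scatter of two such steps

Read the other way round, the two cores stay alike when the 4-chlorophenyl group is present, with a 1.5-fold higher number from compound 2 to compound 4 (0.19 log units; within the scatter), just as they did with the 2-chlorophenyl group, so in these four compounds the effect of the core and the effect of the chlorine's place on the ring can be read separately: the same change on two cores in this assay, a 1.1-fold lower number (0.05 log units; within the scatter) from compound 1 to compound 3 and a 1.5-fold higher number (0.19 log units; within the scatter) from compound 2 to compound 4, 1.7-fold (0.24 log units) apart, within the scatter of two such steps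

This is a single repeat on two cores in this assay, so it supports carrying this change between these two cores but sets no rule for other cores, and it does not show why the 4-chlorophenyl compounds give the lower numbers.

The compounds shown leave open whether the chlorine itself is needed, a question that a plain phenyl group, or a bromine atom or a methoxy group in place of the chlorine, could address. They also leave open whether the step would hold on a third core or in a different cell line.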